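The source may report more compounds than this note shows. Statements on the series, on what has been measured and on what is new or still open speak of the compounds shown alone.

Measured compounds:
compound 1 `CCC1(CCCCN2CCN(c3ccccc3)CC2)C(=O)Nc2ccccc21` gives 2.07 nM
compound 2 `CCC1(CCCCN2CCN(c3ccc(Cl)c(Cl)c3)CC2)C(=O)Nc2ccccc21` gives 0.63 nM

Both numbers come from an assay on CHO cells for displacement of a labelled ligand from 5-hydroxytryptamine receptor 7 (Homo sapiens); on this read-out higher numbers stand for weaker inhibition and lower numbers for stronger inhibition. Among the compounds with values here, compound 2 holds the lower of the two numbers, and the only measured step that leads to it is a 3.3-fold lower number from compound 1 to compound 2 (0.52 log units; beyond the scatter), a separation larger than the usual scatter of repeated measurements. Compound 3 `CCC1(CCCCN2CCN(c3ccc(C)c(Cl)c3)CC2)C(=O)Nc2ccccc21` has not yet been tested in this assay. The change from compound 2 to compound 3 is methyl in place of chloro on an aromatic carbon. Within the data shown here, no measured step exchanges a chloro for a methyl, so the only guidance comes from the step of a 3.3-fold lower number from compound 1 to compound 2 (0.52 log units; beyond the scatter), in which replacing the phenyl with a 3,4-dichlorophenyl lowered the number modestly. Compound 3 keeps one of those chloro groups and carries a methyl where the other stood, so the expected step of a 1.4-fold higher number from compound 2 to compound 3 (0.15 log units; within the scatter) is small, probably within the scatter, with a slight lean toward a higher number. Compound 3 is estimated at 0.9 nM, with a range from 0.3 nM to 2.7 nM.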

Compound 3, inhibition constant: 0.66 nM
For compound 3 the middle estimate is 1.4-fold (0.13 log units) above the measured one; the measured number falls inside the stated range.
By their numbers in this assay, from the lowest: compounds 2 and 3 (each within the scatter of the next); then compound 1.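

In this assay the step is a 1.0-fold higher number from compound 2 to compound 3 (0.02 log units; within the scatter) and stays within the scatter, so on this read-out a methyl at this position, ortho to a chloro group and para to a large group, cannot be told apart from the chloro it replaces. The advantage over the plain phenyl also remains after this exchange: a 3.1-fold lower number from compound 1 to compound 3 (0.50 log units; beyond the scatter) is a step that lies beyond the scatter, as does a 3.3-fold lower number from compound 1 to compound 2 (0.52 log units; beyond the scatter) in the earlier comparison. Nothing available here gives a measured reason why chloro and methyl match at this position.

The compounds shown leave open whether a phenyl carrying only the chloro or only the methyl would keep the lower number, which would tell whether both groups are needed. They also leave open how much room this position allows, since a larger or different group here, such as ethyl, methoxy or trifluoromethyl, could either match these two results or depart from them.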